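The source may report more compounds than this note shows. Statements on the series, on what has been measured and on what is new or still open speak of the compounds shown alone.

Of the compounds shown here, three have been measured in an assay on HEK293 cells for positive allosteric modulation of metabotropic glutamate receptor 2 (Rattus norvegicus), read by thallium flux, with a stated time of 2.5 min; on this read-out higher numbers stand for larger maximal responses and lower numbers for smaller maximal responses. Compound 1 `Cc1c(OCCCCOc2ccc(C(=O)O)cc2F)ccc(C(=O)CC2CCCC2)c1O` gives 83.8%, and compound 2 `Cc1c(OCCCCOc2ccc(C(=O)O)cc2Cl)ccc(C(=O)CC2CCCC2)c1O` gives 82.2%; the change a number 1.6 percentage points lower from compound 1 to compound 2 (within the scatter) stays within the scatter. Compound 3 `CCC(=O)c1ccc(OCCCCOc2cccc(C(=O)O)c2C)c(C)c1O` gives 71.3%, the lowest of the three and clearly apart from both others. Compound 4 `CC(=O)c1ccc(OCCCCOc2cccc(C(=O)O)c2C)c(C)c1O` differs from compound 3 only in hydrogen in place of methyl on a saturated chain carbon bound to a carbonyl carbon. Going by the values given here, no measured step touches this part of the shared core; the only measured step concerns a halogen elsewhere and was within the scatter. Compound 4 is therefore expected to sit close to compound 3, with a step of a number 1.3 percentage points lower from compound 3 to compound 4 (within the scatter) not beyond the scatter, estimated at 70% within 55% to 85%.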

Compound 4, largest response reached (reported as percent of maximum), in percent of the reference or control that the assay uses: 79.2%
The estimate for compound 4 lay 9.2 percentage points below the measured number, within the range that was stated.
By their numbers in this assay, from the lowest: compounds 3, 4, 2 and 1 (each within the scatter of the next, the first and the last beyond it).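

Going from propanoyl to acetyl, with hydrogen in place of methyl on a saturated chain carbon bound to a carbonyl carbon, gives a number 7.9 percentage points higher from compound 3 to compound 4 (within the scatter) in this assay. Going by these compounds alone, this is the first measured change at this place, and removing that one carbon leaves the maximal response within the usual scatter. Nothing available gives a reason for this outcome. Still open, as far as these compounds go, is how this same core would respond to a longer chain, such as butanoyl, or to an amine on that chain carbon.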